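From a Fluorophenyl to a Nitrophenyl Ester

The source may report more compounds than this note shows. Statements on the series, on what has been measured and on what is new or still open speak of the compounds shown alone.

Measured compounds:
Compound 1, `COc1cc2ccc(=O)oc2cc1OC(=O)c1c(C)noc1-c1ccc(Cl)cc1`: 10900 nM
Compound 2, `COc1cc2ccc(=O)oc2cc1OC(=O)c1c(C)noc1-c1ccccc1F`: a limit, > 25000 nM
Compound 3, `COc1cc2ccc(=O)oc2cc1OC(=O)c1c(-c2ccccc2F)n[nH]c1C`: a limit, > 25000 nM

All three were tested in a functional assay on HCT-116 cells (Homo sapiens) for inhibition, read by MTT assay, with a stated time of 48 h; on this read-out lower numbers stand for stronger inhibition and higher numbers for weaker inhibition. In that assay compound 1 gives 10900 nM. For compound 2 the assay reports only a limit, > 25000 nM. For compound 3 the assay likewise reports only a limit, > 25000 nM. Compound 3 therefore stands at the limit of > 25000 nM in this assay, at which 2 of the 3 values shown sit, so its true number is not known, only that it lies beyond that edge.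

Compound 4, `COc1cc2ccc(=O)oc2cc1OC(=O)c1c(-c2ccc([N+](=O)[O-])cc2)n[nH]c1C`, differs from compound 3 by 4-nitrophenyl in place of 2-fluorophenyl on an aromatic carbon. For the measured compounds named here, no measured pair carries this exact change. The closest comparison is an at least 2.2-fold higher number from compound 1 to compound 2 (0.36 log units; beyond the scatter), where a 4-chlorophenyl became a 2-fluorophenyl on a different core and inhibition weakened. Compound 4 moves in the opposite direction, away from 2-fluorophenyl toward a 4-nitrophenyl, so a gain of similar, modest size seems the most reasonable expectation, though with compound 3 known only as a limit the step cannot be pinned down. The step from compound 3 to compound 4 is thus expected to be an at least 1.3-fold lower number from compound 3 to compound 4 (0.14 log units; that floor lies within the scatter). Compound 4 is expected to give 18000 nM in this assay, within a range of 5000 nM to 50000 nM.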

Compound 4, half-maximal inhibitory concentration: > 25000 nM
Compound 4 ended at the assay's limit; the forecaster's own chance of this, stated with the estimate: 45%; middle value at least 1.3-fold (0.14 log units) away from the limit.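

No step can be read from compound 3 to compound 4, because both stop at a limit and not at a number: the limit of > 25000 nM in this assay, at which 3 of the 4 values shown sit.

In this assay the compounds shown leave open how far beyond that limit compound 3 and compound 4 truly lie, and so whether 4-nitrophenyl or 2-fluorophenyl gives the stronger inhibition.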